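An amino group on a bromo compound

A few compounds are considered here, and "the series" means these few. Any claim that something is new, unique, unknown or untested is made for them only; others in the source may bear on it.

In a functional assay on MCF7 cells (Homo sapiens) for cytotoxicity, read by MTT assay, with a stated time of 24 h (on this read-out higher numbers stand for weaker inhibition and lower numbers for stronger inhibition), compound 3 (`O=c1nc2ccc(Br)cn2cc1Cc1ccccc1`) reads > 1000000 nM and this is a limit, not a number. Compound 2 (`O=c1nc2ccc(Br)cn2cc1Cc1ccc(Cl)cc1`) reads > 1000000 nM and this is a limit as well. As far as these compounds go, compound 3 therefore stands at the limit of > 1000000 nM in this assay, at which 2 of the 3 values shown sit, and its exact place on the scale is unknown. Among the compounds with values here, the only measured step is a step that the two limits leave unreadable from compound 2 to compound 3 and it offers no size to carry forward.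

Compound 4 (`Nc1cc(Br)cn2cc(Cc3ccccc3)c(=O)nc12`) is compound 3 with a single change (amino in place of hydrogen on an aromatic carbon) that puts amino in place of hydrogen on an aromatic carbon, meta to a bromo group. Within the data shown here, no measured step shows this change directly. The nearest hint is compound 1 (`Nc1cccn2cc(Cc3ccccc3)c(=O)nc12`) which also carries an amino group but has no bromo group. In this assay compound 1 gives 105000 nM as a true number. On that single value, the expected direction is toward stronger inhibition, with the size poorly fixed since the starting point is only a limit. The expected step is an at least 5.0-fold lower number from compound 3 to compound 4 (0.69 log units; beyond the scatter) and it remains a rough estimate. Compound 4 is estimated at 200000 nM with an expected range from 40000 nM to 800000 nM in this assay and a reading at the limit would be no surprise.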

Compound 4, half-maximal inhibitory concentration: > 1000000 nM
Compound 4 ended at the assay's limit; the forecaster's own chance of this, stated with the estimate: 30%; middle value at least 5.0-fold (0.69 log units) away from the limit.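

Compound 4 reads > 1000000 nM in this assay, which is a limit and not a number, so amino at this position, two atoms from the ring nitrogen, does not bring the bromo compound onto the measured part of the scale. Within the data shown here, the result does add one readable comparison: with the amino group present on both sides, the added bromo group gives an at least 9.5-fold higher number from compound 1 to compound 4 (0.97 log units; beyond the scatter), the first step with a size in this set, and it runs toward weaker inhibition. The steps from compound 2 to compound 3 and from compound 3 to compound 4 cannot be read, and most of the set now sits at one mark: the limit of > 1000000 nM in this assay, at which 3 of the 4 values shown sit.

As far as these compounds go, how far past the limit compound 2, compound 3 and compound 4 truly lie remains unknown, so it stays open whether amino changes anything at all when bromo is present. From the compounds shown here alone, it is also open whether a hydroxyl or a methylamino group at this position, or chloro or methyl in place of bromo, would give a true number in this assay.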